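Swapping a Ring-Nitrogen Methyl for Tert-Butoxycarbonyl

This account rests on a few compounds, and the source may have more. Where it says the series, first, only, none or still open, it means among the compounds named here.

Measured so far:
Compound 1, `CC(=O)N1CCc2c(sc(NC(=O)c3ccc(Cl)cc3)c2C(N)=O)C1`, in an ADME assay on RAW264.7 cells (Mus musculus) for cytotoxicity, read by MTT assay, with a stated time of 48 h, tested at 50 uM; a lower number here means less inhibition, a higher number more inhibition at the concentration tested (going by the name of the read-out): 38.4%
Compound 2, `CN1CCc2c(sc(NC(=O)c3ccc(Cl)cc3)c2C(N)=O)C1`, in this assay: 38.5%

Among the compounds with values here, only two compounds have been measured, and compound 2 cannot be set apart from compound 1: the change from one to the other, a number 0.1 percentage points higher from compound 1 to compound 2 (within the scatter), lies within the scatter of this assay. That step was methyl in place of acetyl on the ring nitrogen, and it moved nothing.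

Compound 3, `CC(C)(C)OC(=O)N1CCc2c(sc(NC(=O)c3ccc(Cl)cc3)c2C(N)=O)C1`, changes the same position again: tert-butoxycarbonyl in place of methyl on an amine nitrogen in a ring. Within the data shown here, the single step that bears on this, a number 0.1 percentage points higher from compound 1 to compound 2 (within the scatter), showed that acetyl and methyl on that nitrogen give the same reading, so one exchange at this nitrogen has already proved indifferent. With no other guidance, the step from compound 2 to compound 3 is expected to stay within the scatter as well: a number 0.5 percentage points lower from compound 2 to compound 3 (within the scatter).

The estimate for compound 3 in this assay is 38%, with a range from 25% to 52%.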

Compound 3, a percentage reported as inhibition, at one concentration (the size of the read-out at that concentration, not a potency): 37.3%
Compound 3: middle estimate off by 0.7 percentage points, on the high side, and the stated range covers the measured number.
By their numbers in this assay, from the lowest: compounds 3, 1 and 2 (each within the scatter of the next).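

In this assay, tert-butoxycarbonyl carries 7 heavy atoms where methyl carries 1, yet the exchange gives a number 1.2 percentage points lower from compound 2 to compound 3 (within the scatter) and so no readable change. Tert-butoxy in place of methyl on a carbonyl carbon behaves the same way, with a number 1.1 percentage points lower from compound 1 to compound 3 (within the scatter) as its step, so methyl, acetyl and tert-butoxycarbonyl on this nitrogen cannot be told apart here, even across this spread of group sizes. No measurement is available to explain why the reading holds steady.

On these data alone, whether a different kind of group on this nitrogen, such as a bare hydrogen, a benzyl group or a chain ending in a carboxylic acid, would shift the reading remains open. So does whether a change elsewhere on the shared core would move it at all.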